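A few compounds are considered here, and "the series" means these few. Any claim that something is new, unique, unknown or untested is made for them only; others in the source may bear on it.

In a functional assay on MIA PaCa-2 cells (Homo sapiens) for inhibition, read by MTT assay, with a stated time of 3 days (a higher number here means a weaker inhibitor, a lower number a stronger inhibitor), three compounds have been measured so far:

Compound 1 `O=C([C@@H]1CCCN(S(=O)(=O)c2ccc(S(=O)(=O)C3CCC3)cc2)C1)N1CCC(F)(F)CC1` gives 12.6 nM.
Compound 2 `CCN(CC)S(=O)(=O)c1ccc(S(=O)(=O)N2CCC[C@@H](C(=O)N3CCS(=O)(=O)CC3)C2)cc1` gives 220 nM.
Compound 3 `O=C([C@@H]1CCCN(S(=O)(=O)c2ccc(S(=O)(=O)N3CC[C@@H](O)C3)cc2)C1)N1CCC(F)(F)CC1` gives 135 nM.

Compound 2 has the highest number of the three; its value lies within the scatter of compound 3 and well apart from compound 1. Within the data shown here, the only step between measured compounds is an 11-fold higher number from compound 1 to compound 3 (1.03 log units; beyond the scatter), which alters the group on the sulfonyl sulfur and leaves the amide side untouched. Compound 4 `CCN(CC)S(=O)(=O)c1ccc(S(=O)(=O)N2CCC[C@@H](C(=O)N3CCOCC3)C2)cc1` differs from compound 2 in morpholin-4-yl in place of 1,1-dioxothiomorpholin-4-yl on a carbonyl carbon. Among the measured compounds shown here, no measured pair varies the substituent on this carbonyl carbon, so the data give no direct guide for this assay, and no step beyond the scatter is expected. Compound 4 is therefore estimated at 210 nM (range 70 nM to 650 nM), an expected step of a 1.0-fold lower number from compound 2 to compound 4 (0.02 log units; within the scatter).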

Compound 4, half-maximal inhibitory concentration: 160 nM
Estimate against measurement, compound 4: 1.3-fold (0.12 log units) above; the range from low to high includes it.
By their numbers in this assay, from the lowest: compound 1; then compounds 3, 4 and 2 (each within the scatter of the next).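

Among these compounds, the first reading at this position comes from this assay and stays within the scatter: morpholin-4-yl in place of 1,1-dioxothiomorpholin-4-yl gives a 1.4-fold lower number from compound 2 to compound 4 (0.14 log units; within the scatter) in this pair. On this pair alone, the 8-heavy-atom ring and the 6-heavy-atom ring can therefore stand in for each other on this carbonyl carbon. No evidence is available to explain this result.

On these data alone, it remains open whether a piperazin-1-yl or an open-chain dimethylamino group on this carbonyl carbon would also stay within the scatter. As far as these compounds go, it also remains open whether the same ring change holds with a different group on the sulfonyl sulfur.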